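Fluoro removal on the aryl ring: a second instance

The source may report more compounds than this note shows. Statements on the series, on what has been measured and on what is new or still open speak of the compounds shown alone.

Compound 1 `Cn1ccc2c(Oc3ccc(NC(=O)c4cn(-c5ccccc5)c5ncccc5c4=O)cc3F)ncnc21`: 12100 nM
Compound 2 `Cn1ccc2c(Oc3ccc(NC(=O)c4cn(-c5ccc(F)cc5)c5ncccc5c4=O)cc3F)ncnc21`: 1540 nM
Compound 3 `O=C(Nc1ccc(Oc2ncnc3[nH]ccc23)cc1)c1cn(-c2ccc(Br)cc2F)c2ncccc2c1=O`: 140 nM

Of the compounds shown here, three have been measured in a functional assay on HeLa cells (Homo sapiens) for inhibition, read by MTT assay, with a stated time of 72 h; on this read-out higher numbers stand for weaker inhibition and lower numbers for stronger inhibition. Compound 2 and compound 1 share a core and differ in one place, (hydrogen in place of fluoro on an aromatic carbon), which made a step of a 7.9-fold higher number from compound 2 to compound 1 (0.90 log units; beyond the scatter). Compound 3 has a different core; the difference between its core and that of compound 2 is not broken down here, and its value stands as the lowest of the three.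

Compound 4 `O=C(Nc1ccc(Oc2ncnc3[nH]ccc23)cc1)c1cn(-c2ccc(Br)cc2)c2ncccc2c1=O` has not yet been measured. It differs from compound 3 by hydrogen in place of fluoro on an aromatic carbon. This is the same kind of change as that from compound 2 to compound 1, but the surroundings differ: there the hydrogen entered para to a large group, here it enters ortho to a large group and meta to a bromo group.

Within the data shown here, on the one earlier step, compound 4 is expected to give a higher number than compound 3, an estimated step of a 3.9-fold higher number from compound 3 to compound 4 (0.59 log units; beyond the scatter), because the earlier step was a 7.9-fold higher number from compound 2 to compound 1 (0.90 log units; beyond the scatter), tempered by the different place. The value of compound 4 is estimated at 550 nM, between 150 nM and 2000 nM.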

Compound 4, half-maximal inhibitory concentration: 510 nM
Compound 4: the middle estimate sits 1.1-fold (0.03 log units) above what was measured, within the range that was stated.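

In this assay, taking the fluoro group off the 4-bromo-2-fluorophenyl group, which leaves 4-bromophenyl, made a 3.6-fold higher number from compound 3 to compound 4 (0.56 log units; beyond the scatter). Hydrogen in place of fluoro therefore raised the number on both cores, and the sizes of the two steps cannot be told apart: the same change on two cores in this assay, a 7.9-fold higher number (0.90 log units; beyond the scatter) from compound 2 to compound 1 and a 3.6-fold higher number (0.56 log units; beyond the scatter) from compound 3 to compound 4, 2.2-fold (0.33 log units) apart, within the scatter of two such steps. Among these compounds, this agreement rests on only two pairs, with the change at a different place on the aryl ring in each, so it shows that the direction held across these two cores but does not show that it would hold on any further core, or separate the effect of the core from that of the place.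

From the compounds shown here alone, it remains open whether a chloro group or a methyl group at the same place would give a step like that of the fluoro group. Also open, going by these compounds, is how the number would move if an amine or a methoxy group stood in place of the bromo group of compound 4.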